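This account rests on a few compounds, and the source may have more. Where it says the series, first, only, none or still open, it means among the compounds named here.

In an ADME assay on HEK293 cells (Homo sapiens) for cytotoxicity, read by MTT assay, with a stated time of 72 h (on this read-out higher numbers stand for weaker inhibition and lower numbers for stronger inhibition), compound 1 `O=C(CN1CCN(C(=O)c2ccc(F)cc2)CC1)N1CCN(CCCc2c[nH]c3ccccc23)CC1` gives 141000 nM. For the measured compounds named here, the only other compound measured so far, compound 2 `O=C(CN1CCN(C(=O)c2ccccc2F)CC1)N1CCN(CCCc2c[nH]c3ccccc23)CC1`, gives 133000 nM, so the two stand level within the scatter of repeated measurements. The next structure, compound 3 `COc1ccc2[nH]cc(CCCN3CCN(C(=O)CN4CCN(C(=O)c5ccc(F)cc5)CC4)CC3)c2c1`, keeps the core of compound 1 and changes one thing: methoxy in place of hydrogen on an aromatic carbon. Put simply, this is methoxy in place of hydrogen on an aromatic carbon.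

Going by the values given here, only one measured step is available for comparison, and it bears on this change only indirectly. That step, a 1.1-fold lower number from compound 1 to compound 2 (0.03 log units; within the scatter), puts 2-fluorophenyl in place of 4-fluorophenyl on a carbonyl carbon, which is not where the methoxy enters. Among the compounds with values here, it shows one small structural swap leaving the number within the scatter, but no measured step tests the new group itself. With so little evidence, no direction can be argued, and the expectation stays anchored to compound 1 at 141000 nM. The expected change is no larger than the scatter, a 1.1-fold lower number from compound 1 to compound 3 (0.04 log units; within the scatter). For compound 3, the estimated value is 130000 nM, with an expected range from 65000 nM to 260000 nM.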

Compound 3, half-maximal inhibitory concentration: > 200000 nM
Compound 3 was reported as a limit; the forecaster's own chance of this, stated with the estimate: 10%; at least 1.5-fold (0.18 log units) between middle value and limit.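

In this assay compound 3 is reported only as a limit, > 200000 nM, and not as a true number. Read against compound 1, this gives an at least 1.4-fold higher number from compound 1 to compound 3 (0.15 log units; that floor lies within the scatter), so the floor of the step does not separate the two compounds, although the result offers no sign that methoxy at this carbon gives a lower number. This is the first change shown on the indole itself, as the earlier step only moved the fluorine on the fluorophenyl group, and it replaces 1H-indol-3-yl with 5-methoxy-1H-indol-3-yl; how far the number of compound 3 lies past the floor cannot be read, and the one relevant fact is this: the limit of > 200000 nM in this assay, at which 1 of the 3 values shown sits.

The compounds shown leave open whether a hydroxyl group, a chlorine atom or an amine at this same carbon would give a lower number, a higher number or one within the scatter of compound 1. They also leave open whether methoxy on another carbon of this six-membered ring would give the same reading, and whether a longer ether such as ethoxy would behave as methoxy does here.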